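Acetylcarbonyl in place of butyl at the assay limit

A few compounds are considered here, and "the series" means these few. Any claim that something is new, unique, unknown or untested is made for them only; others in the source may bear on it.

Of the compounds shown here, three sharing one core have been measured so far. In a functional assay on HEK293 cells (Homo sapiens) for cytotoxicity (a higher number here means that more compound is tolerated, a lower number that less compound is tolerated), compound 1 (`COc1ccc([C@H]2CC(=O)N(c3cccc(S(C)(=O)=O)c3)C2)cc1OC1CCCC1`) gives > 10000 nM, which is a limit of the assay and not a number. Compound 2 (`COc1ccc([C@H]2CC(=O)N(c3cccc(NCCCc4ccccc4)c3)C2)cc1OC1CCCC1`) gives > 10000 nM, also a limit. Compound 3 (`CCCCNc1cccc(N2C[C@@H](c3ccc(OC)c(OC4CCCC4)c3)CC2=O)c1`) gives > 10000 nM, likewise only a limit, so it offers no number to start from.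

The next structure is compound 4 (`COc1ccc([C@H]2CC(=O)N(c3cccc(NC(=O)C(C)=O)c3)C2)cc1OC1CCCC1`), and the change leading to it is acetylcarbonyl in place of butyl on a nitrogen on an aromatic ring. For the measured compounds named here, three measured steps bear on this only indirectly, and none of them involves acetylcarbonyl. They are a step that the two limits leave unreadable from compound 1 to compound 2, a step that the two limits leave unreadable from compound 1 to compound 3 and a step that the two limits leave unreadable from compound 2 to compound 3, so none of them has a readable size.

What they do show is that three different groups leave the series at one value, namely (the limit of > 10000 nM in this assay, at which 3 of the 3 values shown sit). On that basis, no step beyond the scatter and no direction is expected in this assay, and the expected step is a step that the limit leaves unreadable from compound 3 to compound 4. For compound 4 the estimate is 15000 nM, with an expected range from 6000 nM to 40000 nM, and the assay is expected to report only a limit again.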

Compound 4, half-maximal cytotoxic concentration: > 10000 nM
Compound 4: only a limit was reported; the forecaster's own chance of this, stated with the estimate: 85%; the middle value does not contradict the limit.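

In this assay compound 4 gives > 10000 nM, which is a limit of the assay and not a number, so its steps from compound 1, compound 2 and compound 3 cannot be read. The series still rests on a single value: the limit of > 10000 nM in this assay, at which 4 of the 4 values shown sit. The compounds shown leave open at what concentration any of them would be cytotoxic, and whether the four differ at all in this assay.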